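Swapping an imidazolyl for isopropoxy on a shared core

This account rests on a few compounds, and the source may have more. Where it says the series, first, only, none or still open, it means among the compounds named here.

The series shares the core seen in compound 1 `Cc1c(F)c(Oc2cccc(C(=N)N)c2)nc(Oc2cccc(C(=O)N3CCOCC3)c2)c1F` and compound 2 `Cc1c(F)c(Oc2cccc(C(=N)N)c2)nc(Oc2cccc(-n3ccnc3)c2)c1F`. In an assay on isolated protein for inhibition of serine protease 1 (Bos taurus) (on this read-out higher numbers stand for weaker inhibition and lower numbers for stronger inhibition), compound 1 gives > 5000 nM, which is a limit of the assay and not a number. In this assay compound 2 gives 4800 nM, the only numerical value among the two results shown. Among the compounds with values here, the step of an at least 1.0-fold lower number from compound 1 to compound 2 (0.01 log units; that floor lies within the scatter) is the single measured change, and it stays within the scatter; the limit at which compound 1 sits is described by the limit of > 5000 nM in this assay, at which 1 of the 2 values shown sits.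

Compound 3 `Cc1c(F)c(Oc2cccc(OC(C)C)c2)nc(Oc2cccc(C(=N)N)c2)c1F` has not yet been measured. It differs from compound 2 by isopropoxy in place of 1H-imidazol-1-yl on an aromatic carbon. The measured step concerns a different exchange at the same aromatic carbon and showed no shift beyond the scatter, so it offers little guidance for the present change and no direction is expected with confidence. Compound 3 is therefore estimated to give 4500 nM in this assay, within a range from 1500 nM to 14000 nM, corresponding to an expected step of a 1.1-fold lower number from compound 2 to compound 3 (0.03 log units; within the scatter).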

Compound 3, inhibition constant: 2900 nM
The estimate for compound 3 lay 1.6-fold (0.19 log units) above the measured number; the range from low to high includes it.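

In this assay, the exchange of 1H-imidazol-1-yl, with its five-membered aromatic ring, for isopropoxy, which has no ring, gives a 1.7-fold lower number from compound 2 to compound 3 (0.22 log units; within the scatter). Within the data shown here, this is the first group at this aromatic carbon, meta to a large group, that carries no ring, and the exchange shows that an aromatic ring in this group is not needed to keep a numerical value in this assay. Against (morpholin-4-yl)carbonyl the exchange gives an at least 1.7-fold lower number from compound 1 to compound 3 (0.23 log units; that floor lies within the scatter), and this step can be read only as a floor because compound 1 stands at a limit of the assay and not at a number: the limit of > 5000 nM in this assay, at which 1 of the 3 values shown sits.

The compounds shown leave open whether any group at this aromatic carbon, such as an amine, a carboxylic acid or a longer alkoxy chain, would shift the number beyond the scatter. They also leave open how large the true step from compound 1 to compound 3 is, since its floor lies within the scatter.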